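A few compounds are considered here, and "the series" means these few. Any claim that something is new, unique, unknown or untested is made for them only; others in the source may bear on it.

Measured compounds:

Compound 1, `Oc1nc2nonc2nc1Nc1ccccc1C(F)(F)F`, gives 10600 nM
Compound 2, `Oc1nc2nonc2nc1Nc1ccccc1OC(F)(F)F`, gives 7100 nM
Compound 3, `Oc1nc2nonc2nc1Nc1ccc(C(F)(F)F)cc1F`, gives 2600 nM

All three were tested in an assay on mitochondria from L6 cells (Rattus norvegicus) for activation, with a stated time of 90 min; on this read-out higher numbers stand for an effect only at larger amounts of compound and lower numbers for an effect already at smaller amounts. Compound 1 and compound 2 share a core and differ in one place: trifluoromethoxy in place of trifluoromethyl on an aromatic carbon. This change gave a 1.5-fold lower number from compound 1 to compound 2 (0.17 log units; within the scatter), so the two compounds cannot be told apart on this read-out. Compound 3 gives the lowest number of the three, and its gap to the other two is beyond the scatter, but how compound 3 differs from compound 1 is not broken down here.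

Compound 4, `Oc1nc2nonc2nc1Nc1ccc(OC(F)(F)F)cc1F`, has not yet been measured in this assay. It differs from compound 3 in one place: trifluoromethoxy in place of trifluoromethyl on an aromatic carbon. Going by the values given here, this is the same kind of change as the one from compound 1 to compound 2, though the surroundings are not identical: in compound 1 the group is ortho to a large group, whereas in compound 3 it is meta to a fluoro group and para to a large group. Among the compounds with values here, the one measured example of this kind of change is small, and there is no other measured pair to show that the different surroundings would alter it. The step from compound 3 to compound 4 is therefore expected to be a 1.3-fold lower number from compound 3 to compound 4 (0.11 log units; within the scatter), because a 1.5-fold lower number from compound 1 to compound 2 (0.17 log units; within the scatter) lay within the scatter. For compound 4 the expected value in this assay is 2000 nM, with a likely range from 900 nM to 4500 nM.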

Compound 4, half-maximal effective concentration: 2300 nM
Estimate against measurement, compound 4: 1.2-fold (0.06 log units) below, within the range that was stated.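

In this assay, putting trifluoromethoxy in place of trifluoromethyl gave a 1.1-fold lower number from compound 3 to compound 4 (0.05 log units; within the scatter), so compound 3 and compound 4 cannot be told apart on this read-out. The earlier pair gave the same picture, and the two steps cannot be separated from each other, so in both measured cases the swap made no difference that this read-out can detect: the same change on two cores in this assay, a 1.5-fold lower number (0.17 log units; within the scatter) from compound 1 to compound 2 and a 1.1-fold lower number (0.05 log units; within the scatter) from compound 3 to compound 4, 1.3-fold (0.12 log units) apart, within the scatter of two such steps

This suggests that, within these two pairs, trifluoromethyl and trifluoromethoxy can stand in for each other without a measurable difference, even though the surroundings of the group are not identical, but two pairs are too few to make this a rule for the series, and they show nothing about why the two groups match or whether they would match on any other core.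

The compounds shown leave open how a quite different group at the same place would compare, such as a nitrile, an amine, a carboxylic acid or a longer alkyl chain. They also leave open how much the fluoro group contributes on its own, as no pair shown differs only in that group.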